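From a methylfuran to a chlorophenyl group

A few compounds are considered here, and "the series" means these few. Any claim that something is new, unique, unknown or untested is made for them only; others in the source may bear on it.

Measured so far in a functional assay on HCT-15 cells (Homo sapiens) for cytotoxicity, read by ELISA, with a stated time of 4 days; a higher number here means a weaker inhibitor, a lower number a stronger inhibitor

Compound 1 `Cc1ccsc1-c1cc(-c2ccoc2)cc(-c2ccc(Cl)cc2)n1` gives 2990 nM
Compound 2 `Clc1ccc(-c2cc(-c3ccco3)cc(-c3ccc(Cl)s3)n2)cc1` gives 1080 nM
Compound 3 `Cc1ccc(-c2cc(-c3ccoc3)cc(-c3ccc(Cl)s3)n2)o1` gives 790 nM

Compound 3 and compound 2 lie within the scatter of each other, while compound 1 stands beyond the scatter on the higher side of compound 3. Compound 4 `Clc1ccc(-c2cc(-c3ccoc3)cc(-c3ccccc3Cl)n2)s1` carries 2-chlorophenyl in place of the 5-methylfuran-2-yl of compound 3 2-chlorophenyl in place of 5-methylfuran-2-yl on an aromatic carbon on an aromatic carbon next to the ring nitrogen. Within the data shown here, no measured pair shows this change alone. Compound 2 also bears a chlorophenyl group and gives 1080 nM and so does compound 1 at 2990 nM so a small move towards a higher number is expected in this assay rather than a lower one. The expected step is a 1.5-fold higher number from compound 3 to compound 4 (0.18 log units; within the scatter) and may not leave the scatter. The estimate for compound 4 is 1200 nM and it is expected to fall between 450 nM and 3200 nM in most repeats.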

Compound 4, half-maximal inhibitory concentration: 1100 nM
Beside the measured number, compound 4's estimate is 1.1-fold (0.04 log units) above it, within the range that was stated.
By their numbers in this assay, from the lowest: compounds 3, 2 and 4 (each within the scatter of the next); then compound 1.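

In this assay, placing 2-chlorophenyl in place of 5-methylfuran-2-yl on the aromatic carbon next to the ring nitrogen gives a 1.4-fold higher number from compound 3 to compound 4 (0.14 log units; within the scatter). At this position, a six-membered aromatic ring of carbon only, with no hydrogen-bond acceptor, therefore reads the same within the scatter as a five-membered aromatic ring with one acceptor. Nothing shown accounts for this result. On these data alone, whether an amine or a carboxylic acid on this carbon would move the number beyond the scatter remains open, as does the effect of changing the furan-3-yl group alone.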